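The source may hold more compounds than are shown below. What is called first, only, known or untested is meant among the compounds shown, and "the series" means these compounds.

Measured so far in this assay:

- compound 1, `O=C(O)c1nnsc1Sc1ccc(Cl)cc1`: > 30000 nM (a limit of the assay, not a number)
- compound 2, `CC(C)c1coc(-c2cccc(CNc3ccc4[nH]nc(C(=O)O)c4c3)c2O)n1`: 87 nM
- compound 3, `CN(C)c1noc(-c2cccc(CNc3ccc4[nH]ncc4c3)c2O)n1`: 12000 nM

Notes. In an assay on isolated protein for inhibition of 2-Hydroxyacid oxidase 1 (Homo sapiens), with stated times of 30 min and 15 min (on this read-out lower numbers stand for stronger inhibition and higher numbers for weaker inhibition), compound 2 holds the lowest of the two numbers obtained. The nearest number is that of compound 3, and the gap between compound 2 and compound 3 lies well beyond the scatter of repeat measurements. For compound 1 the assay gives only a limit, (the limit of > 30000 nM in this assay, at which 1 of the 3 values shown sits), so no number can be set against it.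

The next compound in the series, compound 4, is `Cc1csc(-c2cccc(CNc3ccc4[nH]nc(C(=O)O)c4c3)c2O)n1`. Relative to compound 2 the change is 4-methyl-1,3-thiazol-2-yl in place of 4-isopropyl-1,3-oxazol-2-yl on an aromatic carbon; the carboxylic acid and the rest of the shared core of compound 2 are kept. For the measured compounds named here, no measured pair in the set isolates such an exchange of one five-membered aromatic ring for another, so the size of the step is open. The exchange is small in atom count and leaves donors and acceptors unchanged, so the step from compound 2 to compound 4 in this assay is expected to be modest, at most a slight weakening and possibly within the scatter. Compound 4 is therefore estimated at 150 nM, with a range of 50 nM to 500 nM, which is an expected step of a 1.7-fold higher number from compound 2 to compound 4 (0.24 log units; within the scatter).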

Compound 4, half-maximal inhibitory concentration: 23 nM
Beside the measured number, compound 4's estimate is 6.5-fold (0.81 log units) above it; the whole stated range lies above it.
By their numbers in this assay, from the lowest: compound 4; then compound 2; then compound 3. At a limit, above all of these: compound 1.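

In this assay, for the compounds shown here, the exchange of 4-isopropyl-1,3-oxazol-2-yl for 4-methyl-1,3-thiazol-2-yl gives a 3.8-fold lower number from compound 2 to compound 4 (0.58 log units; beyond the scatter), the only reading so far at this place, on an aromatic carbon ortho to a hydroxy group. The place therefore accepts more than one five-membered aromatic ring with 2 hetero atoms, and the isopropyl group with its oxazole ring is not required for a low number here, since the smaller entering group of 6 heavy atoms does better than the leaving group of 8 with the carboxylic acid and the rest of the shared core kept. The ring and its alkyl group change together in this single step, so the gain cannot be assigned to either one, and nothing measured on the compounds beyond these numbers bears on the result.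

The 4-isopropyl-1,3-thiazol-2-yl and 4-methyl-1,3-oxazol-2-yl groups would separate the ring from the alkyl group, and an unsubstituted 1,3-thiazol-2-yl or a 4-tert-butyl-1,3-thiazol-2-yl would show how much the alkyl group matters at all. As far as these compounds go, what an amide or a tetrazole would do in place of the carboxylic acid also remains open, with that core otherwise held fixed.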